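The compounds below may be only part of what the source reports. "The series", "measured", "known", "first", "only" and "open" are said of these compounds alone.

Measured compounds:
compound 1, `O=S(=O)(Nc1ccc(-c2nc3ccccc3o2)cc1)c1cccc(Cl)c1`: in an ADME assay on HEK293 cells (Homo sapiens) for cytotoxicity, read by resazurin assay, with a stated time of 48 h (on this read-out lower numbers stand for higher toxicity in this test and higher numbers for lower toxicity in this test), compound 1 gives > 100000 nM, a limit of the assay and not a number.
compound 2, `O=S(=O)(Nc1ccc2oc(-c3ccccc3)nc2c1)c1ccc(F)c(C(F)(F)F)c1`: in this assay compound 2 gives > 100000 nM, again a limit of the assay rather than a number.
compound 3, `COc1cccc(S(=O)(=O)Nc2ccc3oc(-c4ccccc4)nc3c2)c1`: in this assay compound 3 gives 63000 nM.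

Among the three, compound 3 is the only one with a number shown; the other two sit at a limit, as stated in the limit of > 100000 nM in this assay, at which 2 of the 3 values shown sit. Nothing can therefore be said about whether compound 3 differs from compound 1 or compound 2 beyond what the limit allows. Within the data shown here, no step between measured compounds that differ in one place is available, so the series offers no measured step to lean on.

Compound 4, `CCc1ccc(S(=O)(=O)Nc2ccc3oc(-c4ccccc4)nc3c2)cc1`, has not yet been measured in this assay. It differs from compound 3 by 4-ethylphenyl in place of 3-methoxyphenyl on a sulfonyl sulfur. The change leaves the shared core untouched and exchanges one six-membered aromatic ring of carbon only for another, with the hydrogen-bond acceptor of the 3-methoxyphenyl group removed. Compound 3 shows 63000 nM. Two of its relatives sit at a limit, as stated in the limit of > 100000 nM in this assay, at which 2 of the 3 values shown sit. The step is expected to be small, if anything towards lower toxicity, at a 1.3-fold higher number from compound 3 to compound 4 (0.10 log units; within the scatter). Compound 4 is therefore estimated at 80000 nM, within a range from 35000 nM to 160000 nM, with a real chance that only a limit is reported.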

Compound 4, half-maximal cytotoxic concentration: 81000 nM
Estimate against measurement, compound 4: 1.0-fold (0.01 log units) below; low and high end bracket the measured number.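

In this assay, among these compounds, replacing 3-methoxyphenyl with 4-ethylphenyl on a sulfonyl sulfur gives a 1.3-fold higher number from compound 3 to compound 4 (0.11 log units; within the scatter), the first measured step between compounds that differ in one place. The hydrogen-bond acceptor counted in the 3-methoxyphenyl group is absent from compound 4, yet the step stays within the scatter. Among the compounds shown here, at this place, then, one six-membered aromatic ring of carbon only can stand in for another, with the same count of heavy atoms, and a number rather than a limit is returned on both sides of the step, which the earlier compounds alone could not show.

Going by these compounds, what stays open is how this place responds to a group of another kind on the sulfonyl sulfur, such as an amine, a carboxylic acid or a longer alkyl chain, and whether the ethyl and methoxy groups could be separated from where each sits on its ring. Compound 1 and compound 2 remain limits of the assay and not numbers: the limit of > 100000 nM in this assay, at which 2 of the 4 values shown sit.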